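From piperidin-4-yl to methyl on compound 2

This account rests on a few compounds, and the source may have more. Where it says the series, first, only, none or still open, it means among the compounds named here.

Values in a functional assay on MDA-MB-231 cells (Homo sapiens) for antiproliferative activity, read by MTT assay, with a stated time of 72 h (a lower number here means a stronger inhibitor, a higher number a weaker inhibitor), so far:
- compound 1 `CC(Nc1ncnc2ccc(-c3cnn(C4CCNCC4)c3)cc12)c1c(Cl)ccc(F)c1Cl` gives 12600 nM as its value
- compound 2 `CC(Nc1nc(N)nc2ccc(-c3cnn(C4CCNCC4)c3)cc12)c1c(Cl)ccc(F)c1Cl` gives 4480 nM as its value
- compound 3 `CC(Oc1ncnc2ccc(-c3cnn(C4CCNCC4)c3)cc12)c1c(Cl)ccc(F)c1Cl` gives 6770 nM as its value

Compound 2 at 4480 nM lies within the scatter of compound 3 at 6770 nM. The gap between compound 2 and compound 1 lies beyond the scatter. Compound 4 `CC(Nc1nc(N)nc2ccc(-c3cnn(C)c3)cc12)c1c(Cl)ccc(F)c1Cl` is reached by methyl in place of piperidin-4-yl on an aromatic nitrogen with methyl in place of piperidin-4-yl on an aromatic nitrogen. For the measured compounds named here, no measured step touches that group. Going by the values given here, the one measured step, a 2.8-fold lower number from compound 1 to compound 2 (0.45 log units; beyond the scatter), is modest, concerns amino in place of hydrogen on an aromatic carbon, and offers only a guide to size. A similarly modest move toward a higher number in this assay is therefore expected, with its direction uncertain. The expected change is a 2.0-fold higher number from compound 2 to compound 4 (0.30 log units; within the scatter) as estimated here. The estimated value for compound 4 is 9000 nM with an expected range of 2500 nM to 30000 nM in this assay.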

Compound 4, half-maximal inhibitory concentration: 7960 nM
Compound 4: middle estimate off by 1.1-fold (0.05 log units), on the high side, within the range that was stated.
By their numbers in this assay, from the lowest: compounds 2, 3, 4 and 1 (each within the scatter of the next, the first and the last beyond it).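

In this assay, for the compounds shown here, the only step at this position, methyl in place of piperidin-4-yl on an aromatic nitrogen, is a 1.8-fold higher number from compound 2 to compound 4 (0.25 log units; within the scatter) and does not separate the two compounds. Activity at this level therefore does not depend on keeping the piperidin-4-yl ring in this pair. No measurement available here bears on the cause of this result.

Going by these compounds, whether a longer chain ending in an amine, or one ending in a carboxylic acid, on this nitrogen would move the value beyond the scatter remains open. On these data alone, whether methyl behaves the same way without the amino group of compound 2 also remains open.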